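Replacing 4-methoxybenzyl with hexyl in the series

The source may report more compounds than this note shows. Statements on the series, on what has been measured and on what is new or still open speak of the compounds shown alone.

Among the measured compounds shown here, in a functional assay on BT-474 cells (Homo sapiens) for inhibition, read by fluorescence, with a stated time of 72 h (a lower number here means a stronger inhibitor of growth, a higher number a weaker inhibitor of growth), compound 1 (`COc1ccc(Cn2cnc3c(Nc4cccc(Cl)c4)nc(N[C@H]4CC[C@H](N)CC4)nc32)cc1`) gives 8200 nM and compound 2 (`CCCCn1cnc2c(NCc3cccc(Cl)c3)nc(N[C@H]3CC[C@H](N)CC3)nc21`) gives 4700 nM, so compound 1 stands within the scatter of the only other measured compound. Compound 3 (`CCCCCCn1cnc2c(Nc3cccc(Cl)c3)nc(N[C@H]3CC[C@H](N)CC3)nc21`) has not yet been measured. It differs from compound 1 by pentyl in place of 4-methoxyphenyl on a saturated chain carbon bound to an aromatic nitrogen, which also reads as 4-methoxybenzyl to hexyl: pentyl in place of 4-methoxyphenyl on a saturated chain carbon bound to an aromatic nitrogen. For the measured compounds named here, no measured pair isolates a change at this place, so the size of the step cannot be read directly from the data. Going by the values given here, with only two close values as a guide, no step beyond the scatter is expected in this assay, and neither direction is favoured. The expected change is a 1.4-fold lower number from compound 1 to compound 3 (0.14 log units; within the scatter). The estimate for compound 3 is 6000 nM, with an expected range of 2300 nM to 15000 nM.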

Compound 3, concentration for 50% growth inhibition: 5100 nM
Estimate against measurement, compound 3: 1.2-fold (0.07 log units) above, within the range that was stated.
By their numbers in this assay, from the lowest: compounds 2, 3 and 1 (each within the scatter of the next).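

Among the compounds shown here, this pair is the first to isolate the group on a saturated chain carbon bound to an aromatic nitrogen: in this assay, 4-methoxybenzyl to hexyl reads a 1.6-fold lower number from compound 1 to compound 3 (0.21 log units; within the scatter). The exchange of 4-methoxyphenyl for pentyl removes the aromatic ring and the hydrogen-bond acceptor of the leaving group, yet this read-out does not tell the two compounds apart. No measurement available here bears on the reason for this result.

Going by these compounds, it remains open whether a carboxylic acid or an amine at the end of the hexyl chain, or a methyl group in its place, would give a step beyond the scatter. On these data alone, it also remains open whether the same exchange would read alike with another group in place of the 3-chloroanilino group of compound 1.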